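Cyclizing the basic amine tail of compound 1

The source may hold more compounds than are shown below. What is called first, only, known or untested is meant among the compounds shown, and "the series" means these compounds.

Three members of this series have been measured in an assay on isolated protein for antagonist activity at advanced glycosylation end product-specific receptor (Homo sapiens), read by ELISA, with a stated time of 60 min; a lower number here means a stronger inhibitor, a higher number a weaker inhibitor. Compound 1 `CCCCc1sc(-c2ccc(Oc3ccc(Cl)cc3)cc2)nc1-c1ccc(OCCCN(CC)CC)cc1` gives 1120 nM, the lowest of the three numbers. Compound 2 `CCCCc1nc(-c2ccc(Oc3ccc(Cl)cc3)cc2)sc1-c1ccc(OCCCN(CC)CC)cc1` gives 2010 nM, which sits within the scatter of compound 1. Compound 3 `CCCCc1sc(NC(=O)c2ccc(OCCCN(CC)CC)cc2)nc1-c1ccc(Oc2ccc(Cl)cc2)cc1` gives 5590 nM, beyond the scatter from compound 1. Among the measured compounds shown here, none of these pairs differs in a single place, so no measured step is available to anchor a forecast.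

Compound 4 `CCCCc1sc(-c2ccc(Oc3ccc(Cl)cc3)cc2)nc1-c1ccc(OCC2CCCN(CC)C2)cc1` differs from compound 1 by 1-ethylpiperidin-3-yl in place of 2-(diethylamino)ethyl on a saturated chain carbon bound to an oxygen on an aromatic ring. For the measured compounds named here, with no comparable step in hand, the change is expected to be small, probably not beyond the scatter in either direction, with a 1.2-fold higher number from compound 1 to compound 4 (0.06 log units; within the scatter) as the expected step. Compound 4 is estimated at 1300 nM, with a range from 500 nM to 3500 nM.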

Compound 4, half-maximal inhibitory concentration: 1910 nM
Estimate against measurement, compound 4: 1.5-fold (0.17 log units) below; the measured number falls inside the stated range.
By their numbers in this assay, from the lowest: compounds 1, 4 and 2 (each within the scatter of the next); then compound 3.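

In this assay, among the compounds shown here, the only single-place comparison is 1-ethylpiperidin-3-yl in place of 2-(diethylamino)ethyl, which gives a 1.7-fold higher number from compound 1 to compound 4 (0.23 log units; within the scatter) for this change. On a saturated chain carbon bound to an oxygen on an aromatic ring, closing the open diethylamino tail into a six-membered ring therefore produces no difference that can be told from the scatter. No evidence bears on why the two tails read alike.

Going by these compounds, whether a morpholine ring, a primary amine or a carboxylic acid at the end of this chain would read differently stays open. So does whether the 1-ethylpiperidin-3-yl tail reads the same on the core of compound 2.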